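The source may hold more compounds than are shown below. What is called first, only, known or untested is meant among the compounds shown, and "the series" means these compounds.

Measured in a functional assay (aorta) for inhibition, with Rattus norvegicus as the target, with a stated time of 8 days; a higher number here means a weaker inhibitor, a lower number a stronger inhibitor:
- compound 1 `Cc1nsc(-c2ccc(N3CCN(c4cccc(C(F)(F)F)c4)CC3)cc2)n1`: 10 nM
- compound 2 `FC(F)(F)c1cccc(N2CCN(c3ccc(-c4ncns4)nn3)CC2)c1`: 70 nM
- compound 3 `CCc1nsc(-c2ccc(N3CCN(c4cccc(C(F)(F)F)c4)CC3)nn2)n1`: 8 nM

Compound 3 lies within the scatter of compound 1, and compound 2 carries the highest number of the three. Compound 4 `Nc1nsc(-c2ccc(N3CCN(c4cccc(C(F)(F)F)c4)CC3)nn2)n1` has amino in place of ethyl on an aromatic carbon, between two ring nitrogen atoms: amino in place of ethyl on an aromatic carbon. Within the data shown here, one measured step bears on this place: an 8.8-fold lower number from compound 2 to compound 3 (0.94 log units; beyond the scatter), with ethyl in place of hydrogen. Among the measured compounds shown here, no amino compound has been measured here, so that step only indicates how far a change at this place can move the number in this assay. A modest rise, smaller than that step, is expected: a 2.5-fold higher number from compound 3 to compound 4 (0.40 log units; beyond the scatter). For compound 4 the estimate is 20 nM, with an expected range of 6 nM to 70 nM.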

Compound 4, half-maximal inhibitory concentration: 20 nM
Compound 4: middle estimate and measured number agree at the digits printed, within the range that was stated.
By their numbers in this assay, from the lowest: compounds 3, 1 and 4 (each within the scatter of the next, the first and the last beyond it); then compound 2.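

In this assay, among these compounds, amino on this aromatic carbon gives a lower number than hydrogen (a 3.5-fold lower number from compound 2 to compound 4 (0.54 log units; beyond the scatter)), so ethyl is not the only group here that improves on hydrogen. Amino does not match ethyl, however (a 2.5-fold higher number from compound 3 to compound 4 (0.40 log units; beyond the scatter)), so the two groups are not interchangeable at this place. Nothing available explains the difference between amino and ethyl.

Still open, as far as these compounds go, is how a propyl chain or a carboxylic acid at this place would compare with ethyl and amino. Also open, from the compounds shown here alone, is whether the amino-for-ethyl step carries over to the core of compound 1.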